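Bromo for methyl in a weakly active pair

A few compounds are considered here, and "the series" means these few. Any claim that something is new, unique, unknown or untested is made for them only; others in the source may bear on it.

Compound 2 `Cc1ccc2nc(-c3ccc(NC(=O)CCc4ccccc4)cc3)[nH]c2c1` gives 60000 nM in an assay on cells for inhibition of matrix metalloproteinase-9 (Homo sapiens), read by fluorescence, with stated times of 15 min and 4 h (a lower number here means a stronger inhibitor, a higher number a weaker inhibitor), the higher of the two numbers at hand. Compound 1 `O=C(CCCc1ccccc1)Nc1ccc(-c2nc3ccc(Br)cc3[nH]2)cc1` gives 58000 nM in this assay, and the two values lie within the scatter of each other. Compound 3 `O=C(CCc1ccccc1)Nc1ccc(-c2nc3ccc(Br)cc3[nH]2)cc1` is not yet measured and differs from compound 2 by bromo in place of methyl on an aromatic carbon. Within the data shown here, no measured pair covers this exchange, so no shift beyond the scatter is expected in this assay, given that compound 1, which also carries bromo, gives 58000 nM. Compound 3 is expected to give about 60000 nM in this assay, between 25000 nM and 140000 nM, a step of no change at the digits printed from compound 2 to compound 3 (within the scatter) expected to stay within the scatter.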

Compound 3, half-maximal inhibitory concentration: 11500 nM
Beside the measured number, compound 3's estimate is 5.2-fold (0.72 log units) above it; measured number below the stated range.
By their numbers in this assay, from the lowest: compound 3; then compounds 1 and 2 (each within the scatter of the next).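

In this assay, bromo in place of methyl on this aromatic carbon is not a neutral exchange, giving (a 5.2-fold lower number from compound 2 to compound 3 (0.72 log units; beyond the scatter)). With bromo held, phenyl in place of benzyl on the saturated chain gives (a 5.0-fold lower number from compound 1 to compound 3 (0.70 log units; beyond the scatter)), so among these compounds bromo alone does not bring the lower number; the chain counts as well. Nothing at hand gives a reason for either step.

Open, from the compounds shown here alone, is whether chloro or methoxy on the same aromatic carbon would follow bromo or methyl. Also open, going by these compounds, is how a shorter chain would read with bromo held.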